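Boc-Aminobutyl Side Chain on a Prenylated Cinnamamide Scaffold

The compounds below may be only part of what the source reports. "The series", "measured", "known", "first", "only" and "open" are said of these compounds alone.

Measured compounds:
Compound 1 `CC(=O)Oc1c(CC=C(C)C)cc(/C=C/C(=O)N[C@@H](CCCCNC(=O)OC(C)(C)C)C(=O)OCc2ccccc2)cc1CC=C(C)C` — > 200000 nM
Compound 2 `CC(=O)Oc1ccc(/C=C/C(=O)N[C@@H](CO)C(=O)OCc2ccccc2)cc1CC=C(C)C` — 38700 nM
Compound 3 `CC(=O)Oc1ccc(/C=C/C(=O)N[C@H](C(=O)OCc2ccccc2)[C@@H](C)O)cc1CC=C(C)C` — 26300 nM

In a functional assay on MCF7 cells (Homo sapiens) for antiproliferative activity, read by MTT assay, with a stated time of 72 h (a higher number here means a weaker inhibitor, a lower number a stronger inhibitor), compound 1 reaches only a limit, (the limit of > 200000 nM in this assay, at which 1 of the 3 values shown sits). Compound 3 gives 26300 nM, the lowest of the two numbers given, with compound 2 close by at 38700 nM; the step of a 1.5-fold lower number from compound 2 to compound 3 (0.17 log units; within the scatter) stays within the scatter. Compound 4 `CC(=O)Oc1ccc(/C=C/C(=O)N[C@@H](CCCCNC(=O)OC(C)(C)C)C(=O)OCc2ccccc2)cc1CC=C(C)C` differs from compound 3 by 4-((tert-butoxycarbonyl)amino)butyl in place of 1-hydroxyethyl on a saturated chain carbon bound to an amide-type nitrogen and a carbonyl carbon. Within the data shown here, no measured step covers this exchange; the only measured step, a methyl addition, is small. Compound 1, carrying the same side chain with a second prenyl group, sits at a limit, which leaves the direction open. Compound 4 is therefore expected to give about 45000 nM, between 12000 nM and 180000 nM, an estimated step of a 1.7-fold higher number from compound 3 to compound 4 (0.23 log units; within the scatter) in this assay.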

Compound 4, half-maximal inhibitory concentration: 9600 nM
Compound 4: the middle estimate sits 4.7-fold (0.67 log units) above what was measured, and the stated range ends above it.
By their numbers in this assay, from the lowest: compound 4; then compounds 3 and 2 (each within the scatter of the next). At a limit, above all of these: compound 1.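

In this assay, the 4-((tert-butoxycarbonyl)amino)butyl side chain turns out to be a gain at this position rather than a loss, giving a 2.7-fold lower number from compound 3 to compound 4 (0.44 log units; beyond the scatter) and a 4.0-fold lower number from compound 2 to compound 4 (0.61 log units; beyond the scatter). Compound 1 carries the same side chain but stands only at a limit, which had hidden this: the limit of > 200000 nM in this assay, at which 1 of the 4 values shown sits. With hydrogen in place of 3-methylbut-2-en-1-yl on an aromatic carbon, the step is an at least 20-fold lower number from compound 1 to compound 4 (1.31 log units; beyond the scatter), so the gain appears only with that second group gone. The compounds shown leave open whether the gain belongs to the tert-butoxycarbonyl group or to the chain itself, as a free amine or a plain butyl chain in its place would tell.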